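Arylsulfonyl in place of methanesulfonyl on a calpain-1 inhibitor

This account rests on a few compounds, and the source may have more. Where it says the series, first, only, none or still open, it means among the compounds named here.

Measured compounds:
compound 1, `CC(C)CC[C@H](NS(=O)(=O)c1ccc(F)cc1)C(=O)N[C@@H](C=O)CC(C)C`, 260 nM
compound 2, `CC(C)C[C@H](C=O)NC(=O)[C@@H](NS(C)(=O)=O)C(C)C`, 830 nM
compound 3, `CC(C)[C@H](NS(=O)(=O)c1ccc(F)cc1)C(=O)N[C@H](C)C=O`, 630 nM

In an assay on isolated protein (Sus scrofa) for inhibition of Calpain-1 catalytic subunit (Homo sapiens) (a higher number here means a weaker inhibitor, a lower number a stronger inhibitor), compound 2 gives the highest of the three numbers. Its nearest neighbour is compound 3, which gives a number lower within the scatter, so the two cannot be ordered. Compound 1, with its aryl sulfonamide, gives a number lower than compound 2 by more than the scatter.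

Compound 4, `CC(C)C[C@H](C=O)NC(=O)[C@@H](NS(=O)(=O)c1ccc(Cl)cc1)C(C)C`, keeps the core of compound 2 and differs in one place: 4-chlorophenyl in place of methyl on a sulfonyl sulfur. Going by the values given here, no step between measured compounds matches this change directly. What the numbers show is that the two compounds carrying an aryl on the sulfonyl sulfur, compound 1 and compound 3, give lower values than compound 2, and that this holds for compound 1 beyond the scatter while compound 3 stays within it.

From this, compound 4 is expected to give a lower number than compound 2 in this assay, with the step from compound 2 to compound 4 estimated as a 3.3-fold lower number from compound 2 to compound 4 (0.52 log units; beyond the scatter), which is beyond the scatter but modest. Compound 4 is therefore estimated at 250 nM, in a range from 80 nM to 800 nM.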

Compound 4, half-maximal inhibitory concentration: 31 nM
Compound 4: middle estimate off by 8.1-fold (0.91 log units), on the high side; measured number outside the range, below it.
By their numbers in this assay, from the lowest: compound 4; then compound 1; then compounds 3 and 2 (each within the scatter of the next).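

With the core of compound 2 held fixed, 4-chlorophenyl in place of methyl on a sulfonyl sulfur gives, in this assay, a 27-fold lower number from compound 2 to compound 4 (1.43 log units; beyond the scatter), which is a large step. Compound 1 and compound 3 also carry an aryl on the sulfonyl sulfur, but each differs from compound 2 in other places as well, so neither could isolate this position; this step reads the change at that one place and shows that the position alone can move the number by a large amount. The compounds shown offer no measurement that explains why the step is this large.

The step cannot be divided between the six-membered aromatic ring and its chlorine, as the series holds no plain phenyl on the shared core, and 4-fluorophenyl appears only on compounds that differ from compound 4 in other places. Also open, from the compounds shown here alone, is how this position would respond to a benzyl group, a 4-methoxyphenyl group or a longer chain such as butyl on the sulfonyl sulfur, and whether the step would carry over to the cores of compound 1 and compound 3.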